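The source may hold more compounds than are shown below. What is called first, only, known or untested is meant among the compounds shown, and "the series" means these compounds.

Compound 1, `C=C[C@@](C)(/C=C/c1ccc(Nc2cc(F)cc(F)c2)cc1)CCC=C(C)C`, gives > 43400 nM in a functional assay on NALM-6 cells (Homo sapiens) for cytotoxicity, with a stated time of 72 h (a higher number here means that more compound is needed for the effect, a lower number that less compound is needed), which is a limit of the assay and not a number.
Compound 2, `C=C[C@@](C)(/C=C/c1ccc(Nc2cc(F)c(F)c(F)c2)cc1)CCC=C(C)C`, gives > 43400 nM in this assay, again only a limit.
Compound 3, `C=C[C@@](C)(/C=C/c1ccc(Nc2c(F)cc(F)cc2F)cc1)CCC=C(C)C`, gives > 43400 nM in this assay, again only a limit.

Compound 1 therefore stands nowhere on a scale of numbers: its result is a limit, and the other two results shown are limits as well, so all three sit at the limit of > 43400 nM in this assay, at which 3 of the 3 values shown sit. The three steps among the measured compounds are a step that the two limits leave unreadable from compound 1 to compound 2, a step that the two limits leave unreadable from compound 1 to compound 3 and a step that the two limits leave unreadable from compound 2 to compound 3; none of them has a readable size, and each of them changes only the fluorine pattern on the anilino ring.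

The unmeasured compound 4, `C=C[C@@](C)(/C=C/c1ccc(-c2cccc(Br)c2)cc1)CCC=C(C)C`, departs from compound 1 in a different way: 3-bromophenyl in place of (3,5-difluorophenyl)amino on an aromatic carbon. Within the data shown here, no measured step touches this kind of exchange, since the three steps above all keep the anilino link and vary only fluorine on it. What the data give is that every measured compound sits at a limit, and nothing shows a direction in this assay for compound 4. Compound 4 is therefore expected to give a step of a number no higher from compound 1 to compound 4 (the limit leaves the size open), with the result most likely again a limit. The estimate for compound 4 is 43400 nM, in the range 15000 nM to 120000 nM.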

Compound 4, half-maximal effective concentration: > 43400 nM
Compound 4 gave a limit, no number; the forecaster's own chance of this, stated with the estimate: 70%; the middle value lies on the limit itself.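

No new step can be read: compound 1 and compound 4 both give only a limit in this assay, and so the step between them has no readable size. All the compounds shown sit at one limit: the limit of > 43400 nM in this assay, at which 4 of the 4 values shown sit.

The compounds shown leave open whether 3-bromophenyl in place of (3,5-difluorophenyl)amino, or any change in the fluorine pattern, alters the result in this assay at all.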